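Swapping cyclopropyl for ethyl on compound 1

The source may hold more compounds than are shown below. What is called first, only, known or untested is meant among the compounds shown, and "the series" means these compounds.

In an ADME assay on microsomes from liver (Homo sapiens) for metabolic stability, read by LC-MS, with a stated time of 10 min (a higher number here means that more of the compound is left, a lower number that less of the compound is left), compound 1 `c1cnc2c(c1)CCC[C@@H]2N(CC1CC1)C[C@H]1Cc2c(cccc2N2CCNCC2)CN1` gives 82.1%, the highest of three measured numbers. Compound 2 `CN(C[C@H]1Cc2c(cccc2N2CCN3CCC[C@H]3C2)CN1)[C@H]1CCCc2cccnc21` gives 36.6% and compound 3 `CN(C[C@H]1Cc2c(cccc2N2CCN(c3ncccn3)CC2)CN1)[C@H]1CCCc2cccnc21` gives 35.5%, and compound 1 stands clear of both by more than the usual scatter. Compound 4 `CCCN(C[C@H]1Cc2c(cccc2N2CCNCC2)CN1)[C@H]1CCCc2cccnc21` has not yet been measured. It differs from compound 1 by ethyl in place of cyclopropyl on a saturated chain carbon bound to an amine nitrogen, which also reads as cyclopropylmethyl to propyl. Among the compounds with values here, no measured pair isolates this change, so a small downward step is expected in this assay, starting from compound 1 at 82.1%. The estimated step is a number 10.1 percentage points lower from compound 1 to compound 4 (beyond the scatter). For compound 4 the expected value is 72%, with an estimated range of 50% to 88%.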

Compound 4, percent of the compound remaining: 100%
Beside the measured number, compound 4's estimate is 28 percentage points below it, outside the stated range (above it).
By their numbers in this assay, from the lowest: compounds 3 and 2 (each within the scatter of the next); then compound 1; then compound 4.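

Within the data shown here, this is the first pair to isolate a change at this position: in this assay, ethyl in place of cyclopropyl on a saturated chain carbon bound to an amine nitrogen gives a number 17.9 percentage points higher from compound 1 to compound 4 (beyond the scatter) and shows that the three-membered ring is not needed here for a high number. The open propyl chain does better at this place than cyclopropylmethyl. Nothing available explains this step.

From the compounds shown here alone, whether a longer chain such as butyl, or a chain carrying an ether oxygen, would hold this number remains open. So does whether the same swap gives a similar step on a core bearing a group other than the piperazine of compound 1.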